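Shared-core series: methoxy to cyano, compound 1 to compound 3

A few compounds are considered here, and "the series" means these few. Any claim that something is new, unique, unknown or untested is made for them only; others in the source may bear on it.

Measured so far in a functional assay on MCF7 cells (Homo sapiens) for inhibition, read by MTT assay, with a stated time of 72 h; on this read-out lower numbers stand for stronger inhibition and higher numbers for weaker inhibition:
compound 1 `COc1cccc(Nc2nc(Oc3cccc(NC(=O)C=C(C)C)c3)c3sccc3n2)c1` — 35800 nM
compound 2 `CC/C=C/C(=O)Nc1cccc(Oc2nc(Nc3cccc(OC)c3)nc3ccsc23)c1` — 43400 nM

Compound 1 gives the lower of the two numbers, but the step of a 1.2-fold higher number from compound 1 to compound 2 (0.08 log units; within the scatter) is within the scatter, so no order between compound 1 and compound 2 is claimed. Compound 3 `CC(C)=CC(=O)Nc1cccc(Oc2nc(Nc3cccc(C#N)c3)nc3ccsc23)c1` arises from compound 1 by cyano in place of methoxy on an aromatic carbon, read one bond further out as (3-methoxyphenyl)amino to (3-cyanophenyl)amino. For the measured compounds named here, no measured step touches this part of the structure; the only step on record alters the amide side. No direction is therefore supported, and compound 3 is expected to show a 1.0-fold higher number from compound 1 to compound 3 (0.00 log units; within the scatter) in this assay, not beyond the scatter. The estimate for compound 3 is 36000 nM, with a range from 14000 nM to 90000 nM.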

Compound 3, half-maximal inhibitory concentration: 41100 nM
Estimate against measurement, compound 3: 1.1-fold (0.06 log units) below, and the stated range covers the measured number.
By their numbers in this assay, from the lowest: compounds 1, 3 and 2 (each within the scatter of the next).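

In this assay, the (3-methoxyphenyl)amino part now has a step of its own, a 1.1-fold higher number from compound 1 to compound 3 (0.06 log units; within the scatter), so cyano in place of methoxy on this aromatic carbon shows no change beyond the scatter. The earlier step touched only the amide side, and this reading rests on a single pair. No other data on the result are at hand to interpret it.

From the compounds shown here alone, whether an amine or a carboxylic acid on this aromatic carbon would shift the number stays open. So does whether the cyano change reads the same with the but-1-en-1-yl amide of compound 2.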